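A Second Nitro Group on a Compound Without a Number

This account rests on a few compounds, and the source may have more. Where it says the series, first, only, none or still open, it means among the compounds named here.

Of the compounds shown here, three built on one core have been tested in a functional assay on A549 cells (Homo sapiens) for inhibition (a lower number here means a stronger inhibitor, a higher number a weaker inhibitor), and none has yet given a true number. Compound 1 `COc1ccc(/C=C/c2ccc3ccccc3c2)cc1` reads > 5000 nM, which is a limit of the assay. Compound 2 `COc1ccc(/C=C/c2ccc3ccccc3c2)cc1[N+](=O)[O-]`, the starting point here, reads > 5000 nM, and this too is a limit. Compound 3 `COc1ccc(/C=C\c2ccc3ccccc3c2)cc1[N+](=O)[O-]` reads > 20000 nM, again a limit. Where compound 2 stands is therefore known only as one side of a boundary.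

Compound 4 `COc1c([N+](=O)[O-])cc(/C=C/c2ccc3ccccc3c2)cc1[N+](=O)[O-]` takes compound 2 and adds one change: nitro in place of hydrogen on an aromatic carbon. The new nitro sits ortho to a methoxy group and meta to the existing nitro group.

Going by the values given here, the closest precedent is the same swap of nitro for hydrogen, seen in a step that the two limits leave unreadable from compound 1 to compound 2. The other measured change, a step that the two limits leave unreadable from compound 2 to compound 3, rests on the fact that compounds 2 and 3 differ only in the configuration as drawn and involves no added group. Neither step offers a size to carry forward, so no clear move in either direction is expected in this assay. The expected change is a step that the limit leaves unreadable from compound 2 to compound 4, and it is a weakly founded guess. For compound 4 the estimated value is 10000 nM, with an expected range from 3000 nM to 30000 nM.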

Compound 4, half-maximal inhibitory concentration: > 5000 nM
Compound 4 was reported as a limit; the forecaster's own chance of this, stated with the estimate: 80%; the middle value lies beyond the limit too.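

In this assay compound 4 gives > 5000 nM, which is a limit of the assay and not a number. Compound 2 also gives only a limit, so the step between compound 2 and compound 4 cannot be read. The compounds shown leave open how strongly any of them inhibits, and whether the second nitro group changes that at all.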